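Hydrazone aryl variation: from compound 3 to compound 4

The source may hold more compounds than are shown below. What is called first, only, known or untested is meant among the compounds shown, and "the series" means these compounds.

Measured so far:
compound 1 `CN(C)CCn1cnnc1-c1cc(Oc2ccc(NC(=O)N/N=C/c3ccc(F)cc3F)cc2F)ccn1`: 1900 nM
compound 2 `CN(C)CCn1cnnc1-c1cc(Oc2ccc(NC(=O)N/N=C/c3ccc(Cl)cc3)cc2F)ccn1`: 1370 nM
compound 3 `CN(C)CCn1cnnc1-c1cc(Oc2ccc(NC(=O)N/N=C/c3ccc(O)c(F)c3)cc2F)ccn1`: > 100000 nM

In a functional assay on U-87MG ATCC cells (Homo sapiens) for cytotoxicity, read by MTT assay, with a stated time of 72 h (on this read-out lower numbers stand for stronger inhibition and higher numbers for weaker inhibition), compound 1 gives 1900 nM and compound 2 gives 1370 nM; the pair differ by a 1.4-fold lower number from compound 1 to compound 2 (0.14 log units; within the scatter). For compound 3 the assay returns only a limit, > 100000 nM, and no number. Compound 3 therefore stands at the weak end of what has been measured: the steps of an at least 52-fold higher number from compound 1 to compound 3 (1.72 log units; beyond the scatter) and an at least 72-fold higher number from compound 2 to compound 3 (1.86 log units; beyond the scatter) are both large, and both end at the limit of > 100000 nM in this assay, at which 1 of the 3 values shown sits.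

Compound 4 `CN(C)CCn1cnnc1-c1cc(Oc2ccc(NC(=O)N/N=C/c3cccc(O)c3)cc2F)ccn1` differs from compound 3 in one place: 3-hydroxyphenyl in place of 3-fluoro-4-hydroxyphenyl on a carbon with a double bond to nitrogen. The hydroxyphenyl ring is retained, the fluorine is absent. Among the measured compounds shown here, the only steps that touch this region are the two that lead into compound 3, and both point toward weak inhibition once a hydroxyphenyl ring is present. For the measured compounds named here, no measured step separates the effect of the hydroxyl from that of the fluorine, so the change an at least 1.6-fold lower number from compound 3 to compound 4 (0.22 log units; that floor lies within the scatter) is expected to be small or none beyond the scatter. Compound 4 is estimated at 60000 nM in this assay, within 10000 nM to 100000 nM, with a fair chance that only a limit is again reported.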

Compound 4, half-maximal inhibitory concentration: > 100000 nM
Compound 4: a limit, no number (the forecaster's own chance of this, stated with the estimate: 50%); middle value at least 1.6-fold (0.22 log units) from the limit.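

In this assay compound 4, with no fluorine on its hydroxyphenyl ring, returns only a limit, > 100000 nM, and the step from compound 3 to compound 4 joins two limits and cannot be read. The fluorine of compound 3 is therefore not required for weak inhibition at this position, and the steps from the two halogen-bearing aryl rings are large: an at least 72-fold higher number from compound 2 to compound 4 (1.86 log units; beyond the scatter), and an at least 52-fold higher number from compound 1 to compound 4 (1.72 log units; beyond the scatter). Among the compounds shown, both hydroxyphenyl hydrazones sit at the limit, while the two without a hydroxyl return numbers: the limit of > 100000 nM in this assay, at which 2 of the 4 values shown sit.

As far as these compounds go, how far compound 3 and compound 4 lie past that limit remains open, as does whether the hydroxyl itself accounts for the difference. A methoxyphenyl, an aminophenyl or an unsubstituted phenyl on this carbon would bear on that question.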